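This account rests on a few compounds, and the source may have more. Where it says the series, first, only, none or still open, it means among the compounds named here.

Compound 1 `O=C(/C(=C\c1csc([N+](=O)[O-])c1)S(=O)(=O)c1ccc(Br)cc1)c1ccc(Br)cc1`: 1000 nM
Compound 2 `CSc1ccc(/C=C(\C(=O)c2ccc(Br)cc2)S(=O)(=O)c2ccc(C)cc2)cc1`: 1000 nM
Compound 3 `O=C(/C(=C\c1ccc([N+](=O)[O-])c(O)c1)Sc1ccc(Br)cc1)c1c(F)c(F)c(F)c(F)c1F`: 1000 nM

All three measured compounds were tested in a functional assay on DU-145 cells (Homo sapiens) for inhibition, read by trypan blue exclusion, with a stated time of 96 h; a higher number here means a weaker inhibitor of growth, a lower number a stronger inhibitor of growth. In this assay compound 1 gives 1000 nM, and compounds 2 and 3 sit level with it at the digits shown, so nothing among the three can be called stronger or weaker; their values lie within the scatter of one another. The shared core of these compounds carries a ring on a double-bonded chain carbon, and the ring differs from compound to compound without any visible effect on the numbers so far.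

The unmeasured compound 4 `O=C(/C(=C\c1ccc(Br)c(O)c1)S(=O)(=O)c1ccc(Br)cc1)c1ccc(Br)cc1` is built from compound 1 by one change:

4-bromo-3-hydroxyphenyl in place of 5-nitrothiophen-3-yl on a double-bonded chain carbon bound to a double-bonded chain carbon

Going by the values given here, no step between measured compounds has been recorded, so there is no direct precedent for this exchange. Since the three measured compounds, with their different rings, all land at the same value, the step of no change at the digits printed from compound 1 to compound 4 (within the scatter) is expected to be none beyond the scatter. For compound 4 the expected value is therefore 1000 nM, with a range from 300 nM to 3000 nM.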

Compound 4, concentration for 50% growth inhibition: 50000 nM
For compound 4 the middle estimate is 50-fold (1.70 log units) below the measured one; the measured number lies above the stated range.
By their numbers in this assay, from the lowest: compounds 1, 2 and 3 (each within the scatter of the next); then compound 4.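

Exchanging 5-nitrothiophen-3-yl for 4-bromo-3-hydroxyphenyl on a double-bonded chain carbon bound to a double-bonded chain carbon brings a 50-fold higher number from compound 1 to compound 4 (1.70 log units; beyond the scatter) in this assay, a large loss of growth inhibition. Going by these compounds alone, the group at this place can therefore matter a great deal, something the earlier compounds could not show, as no two of them differ in one place only. No measurement here tells why this exchange has so large an effect.

The exchange replaces the ring and its substituents all at once, so the compounds shown do not separate the share of the ring itself from that of the nitro group, the bromine or the hydroxyl. Also open, going by these compounds, is how a ring carrying an amine or a carboxylic acid at this place would read in this assay.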